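Indolyl for isopropoxyphenyl: a cytotoxicity step foreseen

The compounds below may be only part of what the source reports. "The series", "measured", "known", "first", "only" and "open" are said of these compounds alone.

Compound 3 `CCOC(=O)CCCCCOc1cccc(CN(C(=O)c2ccc(-c3cccc(OC(C)C)c3)cc2)C(C)C)c1` carries a 3-isopropoxyphenyl group on the shared core; compound 1 `CCOC(=O)CCCCCOc1cccc(CN(C(=O)c2ccc(-c3cccc(-c4ccccc4)c3)cc2)C(C)C)c1` carries a phenyl and compound 2 `CCOC(=O)CCCCCOc1cccc(CN(C(=O)c2ccc(-c3cccc(C(C)=O)c3)cc2)C(C)C)c1` an acetyl at the same carbon. In an ADME assay on HepG2 cells (Homo sapiens) for cytotoxicity, read by CellTiter-Glo and resazurin assay, with a stated time of 72 h (a higher number here means that more compound is needed for the effect, a lower number that less compound is needed), compound 3 gives only a limit of the assay, > 26000 nM. Compound 1 likewise gives a limit, > 26000 nM. Compound 2 also gives a limit, > 26000 nM. All three values sit at the limit of > 26000 nM in this assay, at which 3 of the 3 values shown sit, so compound 3 cannot be ranked against either neighbour, and the steps a step that the two limits leave unreadable from compound 1 to compound 2, a step that the two limits leave unreadable from compound 1 to compound 3 and a step that the two limits leave unreadable from compound 2 to compound 3 remain unreadable in size and direction.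

Compound 4 `CCOC(=O)CCCCCOc1cccc(CN(C(=O)c2ccc(-c3ccc4cc[nH]c4c3)cc2)C(C)C)c1` differs from compound 3 by 1H-indol-6-yl in place of 3-isopropoxyphenyl on an aromatic carbon. For the measured compounds named here, no measured step reads out a shift for any exchange at this carbon, and all three show the same limit, so compound 4 is expected to show no step beyond the scatter, a step that the limit leaves unreadable from compound 3 to compound 4. Compound 4 is therefore estimated at 30000 nM in this assay, within 13000 nM to 70000 nM, most likely again reported only as a limit.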

Compound 4, half-maximal effective concentration: > 26000 nM
Compound 4: a limit, no number; the forecaster's own chance of this, stated with the estimate: 85%; the middle value does not contradict the limit.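

No step between compound 4 and compound 1, compound 2 or compound 3 can be read in this assay, because each gives only a limit and no number: the limit of > 26000 nM in this assay, at which 4 of the 4 values shown sit.

The compounds shown leave open whether any exchange at this aromatic carbon shifts cytotoxicity, and at what concentration any of the four would reach the effect.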